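The source may report more compounds than this note shows. Statements on the series, on what has been measured and on what is new or still open speak of the compounds shown alone.

Measured so far in a functional assay on HCT-116 cells (Homo sapiens), read by MTT assay, with a stated time of 72 h; on this read-out higher numbers stand for weaker inhibition and lower numbers for stronger inhibition:
compound 1 `COc1nc(N)nc2c1c(-c1cc3ccccc3o1)cn2[C@@H]1O[C@H](CO)[C@@H](O)[C@H]1O`: > 20000 nM
compound 2 `COc1ncnc2c1c(I)cn2[C@@H]1O[C@H](CO)[C@@H](O)[C@H]1O`: > 20000 nM
compound 3 `CNc1ncnc2c1c(-c1ccccc1)cn2[C@@H]1O[C@H](CO)[C@@H](O)[C@H]1O`: > 100000 nM

Each of these three values is a limit of the assay and not a number. Compound 2 stands at such a limit in this assay. Two of the three values sit at the limit of > 20000 nM in this assay, at which 2 of the 3 values shown sit, the third at the limit of > 100000 nM in this assay, at which 1 of the 3 values shown sits. Going by the values given here, no measured pair differs in only one place, so no measured step is available.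

Compound 4 `COc1ncnc2c1c(-c1ccco1)cn2[C@@H]1O[C@H](CO)[C@@H](O)[C@H]1O` is the untested member. It differs from compound 2 by furan-2-yl in place of iodo on an aromatic carbon. Since every measured value is a limit, the expected step is a step that the limit leaves unreadable from compound 2 to compound 4, nothing beyond the scatter of this assay. Compound 4 is expected to give about 30000 nM, within 10000 nM to 100000 nM, and most probably again only as a limit.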

Compound 4, half-maximal inhibitory concentration: 40 nM
For compound 4 the middle estimate is 750-fold (2.88 log units) above the measured one, and the stated range ends above it.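

In this assay, furan-2-yl in place of iodo gives an at least 500-fold lower number from compound 2 to compound 4 (2.69 log units; beyond the scatter), the only readable step in the series, and compound 4 is the only member shown whose value is not a limit. The aromatic carbon two ring bonds from the ring nitrogen thus responds strongly to the group it carries. Nothing available here accounts for the size of this step.

On these data alone, whether the gain depends on the furan-2-yl ring itself stays open. A thiophen-2-yl group or an amine on this same carbon would address that question.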